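Inversion of the ring hydroxyl stereocentre in a lactone series

The compounds below may be only part of what the source reports. "The series", "measured", "known", "first", "only" and "open" are said of these compounds alone.

Compound 1 `O=C1C[C@H](O)C[C@@H](/C=C/c2ccc(Cl)cc2Cl)O1` and compound 2 `C[C@]1(O)CC(=O)O[C@H](/C=C/c2ccc(Cl)cc2Cl)C1` share the shared core. In an assay for inhibition of 3-hydroxy-3-methylglutaryl-coenzyme A reductase (Rattus norvegicus), tested at 4 ug/mL (a higher number here means a stronger effect of the compound at the concentration tested, a lower number a weaker effect), compound 1 gives 0%, while compound 2 gives 36%, the higher of the two numbers, a gap beyond the scatter. Compound 3 `C[C@@]1(O)CC(=O)O[C@H](/C=C/c2ccc(Cl)cc2Cl)C1` is not yet measured and differs from compound 2 thus: the two compounds have the same atoms and bonds and differ only in configuration as drawn: 1 of 3 stereo elements differ; a stereocentre at a saturated ring carbon is drawn R in compound 2 and S in compound 3. Among the measured compounds shown here, no measured pair covers such a change; a downward step of modest size in this assay is expected, possibly just beyond the scatter. Compound 3 is estimated at 20%, ranging from 0% to 45%. This corresponds to an expected step of a number 16 percentage points lower from compound 2 to compound 3 (beyond the scatter).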

Compound 3, a percentage reported as inhibition, at one concentration (the size of the read-out at that concentration, not a potency): 7%
Compound 3: middle estimate off by 13 percentage points, on the high side; low and high end bracket the measured number.
By their numbers in this assay, from the lowest: compounds 1 and 3 (each within the scatter of the next); then compound 2.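

In this assay the read-out stands a number 29 percentage points lower from compound 2 to compound 3 (beyond the scatter): at this saturated ring carbon, the drawn configuration counts. The step can be laid on that stereocentre alone: the fact that compounds 2 and 3 differ only in the configuration as drawn. With the configuration of compound 3, methyl in place of hydrogen on the saturated ring carbon gives a number 7 percentage points higher from compound 1 to compound 3 (within the scatter), a change that shows no effect of the methyl in this pair.

As far as these compounds go, whether an ethyl group or a longer chain on this carbon keeps the read-out of compound 2 stays open. So does the effect of an amine in place of the ring hydroxyl.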